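Moving the Fluorine Within the Anilino Ring

A few compounds are considered here, and "the series" means these few. Any claim that something is new, unique, unknown or untested is made for them only; others in the source may bear on it.

Compound 3 `CCCOc1ccc(C(=O)Nc2cccc(Nc3ccccc3F)n2)cc1` sits at the edge of what an in vitro assay on HEK-tsA201 cells for antagonist activity at Neuronal acetylcholine receptor; alpha3/beta4 (Homo sapiens), read by fluorescence and calcium flux (on this read-out higher numbers stand for weaker inhibition and lower numbers for stronger inhibition), can report: in this assay compound 3 gives > 100000 nM, a limit rather than a number. Compound 1 `CCCOc1ccc(C(=O)Nc2cccc(C)n2)cc1` gives 11100 nM. Compound 2 `CCCOc1ccc(C(=O)Nc2cccc(Cl)n2)cc1` gives > 100000 nM, again a limit. The steps of an at least 9.0-fold higher number from compound 1 to compound 2 (0.95 log units; beyond the scatter) and an at least 9.0-fold higher number from compound 1 to compound 3 (0.95 log units; beyond the scatter) both lead away from compound 1, whereas a step that the two limits leave unreadable from compound 2 to compound 3 cannot be read because of the limit of > 100000 nM in this assay, at which 2 of the 3 values shown sit. Compound 4 `CCCOc1ccc(C(=O)Nc2cccc(Nc3ccc(F)cc3)n2)cc1` differs from compound 3 by 4-fluorophenyl in place of 2-fluorophenyl on a nitrogen on an aromatic ring. Among the measured compounds shown here, none of the measured steps moves a fluorine within a ring, so they give no direction for this change. Compound 4 is expected at 150000 nM, within 40000 nM to 600000 nM, the step that the limit leaves unreadable from compound 3 to compound 4 being estimated to stay within the scatter.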

Compound 4, half-maximal inhibitory concentration: > 100000 nM
Compound 4 ended at the assay's limit; the forecaster's own chance of this, stated with the estimate: 70%; the middle value does not contradict the limit.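

In this assay compound 4 gives > 100000 nM, a limit of the assay and not a number. The step is an at least 9.0-fold higher number from compound 1 to compound 4 (0.95 log units; beyond the scatter), so (4-fluorophenyl)amino, like (2-fluorophenyl)amino and chloro, leads away from the methyl group on this aromatic carbon. The steps among compound 2, compound 3 and compound 4 cannot be read, and moving the fluorine therefore yields no size, because all three stand at one limit: the limit of > 100000 nM in this assay, at which 3 of the 4 values shown sit.

As far as these compounds go, whether the fluorine's place matters at all remains open. So does whether a small group such as ethyl or methoxy in place of methyl would keep a readable value or lower it.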